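Swapping Nitro for Chloro in a Cell Growth Series

The compounds below may be only part of what the source reports. "The series", "measured", "known", "first", "only" and "open" are said of these compounds alone.

Of the compounds shown here, three sharing one core have been measured in a functional assay on A549 cells (Homo sapiens) for inhibition, read by XTT assay, with a stated time of 48 h; a higher number here means a weaker inhibitor, a lower number a stronger inhibitor. Compound 1 `COc1ccc(C(=O)/C(=C/c2ccc(Cl)cc2)CCOC(C)=O)cc1` gives 86000 nM in this assay. Compound 2 `COc1ccc(C(=O)/C(=C/c2ccc(Cl)cc2Cl)CC(C)C)cc1`, carrying an isobutyl chain and two chloro groups on its aromatic ring, gives 80300 nM in this assay. Compound 3 `COc1ccc(C(=O)/C(=C/c2ccc([N+](=O)[O-])cc2)CC(C)C)cc1` yields only a limit in this assay, > 100000 nM, and no number. Compound 3 therefore stands at the edge of the measured range, at the limit of > 100000 nM in this assay, at which 1 of the 3 values shown sits, and cannot be placed in order against compound 1 or compound 2.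

The next compound, compound 4 `COc1ccc(C(=O)/C(=C/c2ccc(Cl)cc2)CC(C)C)cc1`, differs from compound 3 in a single position: chloro in place of nitro on an aromatic carbon. Going by the values given here, no measured pair in this set shows this exact exchange, so the size of the step is not known from the data. Compound 1 and compound 2, each bearing chloro on the aromatic ring, both returned numbers rather than limits, so the step from compound 3 to compound 4 is expected to move toward a measurable value, an at least 1.1-fold lower number from compound 3 to compound 4 (0.07 log units; that floor lies within the scatter), toward stronger inhibition. Compound 4 is expected to give about 85000 nM in this assay, with a range from 40000 nM to 180000 nM.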

Compound 4, half-maximal inhibitory concentration: > 100000 nM
Compound 4: no number, only a limit (the forecaster's own chance of this, stated with the estimate: 40%); at least 1.1-fold (0.07 log units) between middle value and limit.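

In this assay compound 4 gives > 100000 nM, which is a limit and not a number. Chloro on this aromatic carbon, para to a large group, is therefore not enough by itself to bring the isobutyl series to a number, and the step between compound 3 and compound 4 cannot be read, since both ends are limits: the limit of > 100000 nM in this assay, at which 2 of the 4 values shown sit. The two other comparisons give only floors that lie within the scatter: hydrogen in place of chloro on an aromatic carbon gives an at least 1.2-fold higher number from compound 2 to compound 4 (0.09 log units; that floor lies within the scatter), and isopropyl in place of acetoxymethyl on a saturated chain carbon gives an at least 1.1-fold higher number from compound 1 to compound 4 (0.06 log units; that floor lies within the scatter), so neither change can be said to matter on these data.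

The compounds shown leave open how far compound 3 and compound 4 lie beyond the limit, and so whether nitro and chloro differ at this position at all. They also leave open whether an amine or a carboxylic acid on this aromatic carbon, or a longer chain in place of the isopropyl, would give a number in this assay.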